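Stripping the sulfonamide nitrogen substituent from compound 3

A few compounds are considered here, and "the series" means these few. Any claim that something is new, unique, unknown or untested is made for them only; others in the source may bear on it.

- compound 1 `Cc1cc(C)nc(NS(=O)(=O)c2ccc(Nc3nncc4ccccc34)cc2)n1` gives 4.9 nM
- compound 2 `O=S(=O)(Nc1nccs1)c1ccc(Nc2nncc3ccccc23)cc1` gives 54 nM
- compound 3 `Cc1cc(NS(=O)(=O)c2ccc(Nc3nncc4ccccc34)cc2)no1` gives 23 nM

These values come from a functional assay on K562 cells (Homo sapiens) for antiproliferative activity, read by sulforhodamine B assay, with a stated time of 72 h (on this read-out lower numbers stand for stronger inhibition and higher numbers for weaker inhibition), and the three compounds differ only in the ring on the sulfonamide nitrogen. Compound 3 stands second highest of the three, closer to compound 2 than to compound 1. The next compound, compound 4 `NS(=O)(=O)c1ccc(Nc2nncc3ccccc23)cc1`, differs from it thus: hydrogen in place of 5-methyl-1,2-oxazol-3-yl on a sulfonamide nitrogen. In words, this is hydrogen in place of 5-methyl-1,2-oxazol-3-yl on a sulfonamide nitrogen.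

Swapping one ring for another there gave an 11-fold higher number from compound 1 to compound 2 (1.04 log units; beyond the scatter) as a large step, a 4.7-fold higher number from compound 1 to compound 3 (0.67 log units; beyond the scatter) as a modest one and a 2.3-fold lower number from compound 2 to compound 3 (0.37 log units; beyond the scatter) as another modest one. Among the compounds with values here, no measured compound lacks the ring, so these steps indicate only the likely size of the change and leave its direction uncertain. In this assay a modest step is expected, estimated as a 2.6-fold higher number from compound 3 to compound 4 (0.42 log units; beyond the scatter) toward weaker inhibition. For compound 4 the estimated value is 60 nM and the expected range runs from 10 nM to 400 nM at this stage.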

Compound 4, half-maximal inhibitory concentration: 14 nM
Compound 4: middle estimate off by 4.3-fold (0.63 log units), on the high side; low and high end bracket the measured number.
By their numbers in this assay, from the lowest: compound 1; then compounds 4 and 3 (each within the scatter of the next); then compound 2.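

In this assay the ring on the sulfonamide nitrogen proves dispensable for compound 3, since replacing it with hydrogen gives a 1.6-fold lower number from compound 3 to compound 4 (0.22 log units; within the scatter) and the two compounds cannot be told apart. The unsubstituted compound 4 also falls among the ring-bearing compounds, with a 3.9-fold lower number from compound 2 to compound 4 (0.59 log units; beyond the scatter) and a 2.9-fold higher number from compound 1 to compound 4 (0.46 log units; beyond the scatter) in the two remaining comparisons. Of the three rings, then, 1,3-thiazol-2-yl gives a higher number than hydrogen, 4,6-dimethylpyrimidin-2-yl gives a lower one, and 5-methyl-1,2-oxazol-3-yl stays within the scatter of hydrogen, while no available data explain these differences.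

The compounds shown leave open where a simple methyl, an acetyl or a 2-aminoethyl chain on this nitrogen would fall relative to hydrogen. They also leave open whether the lower number of compound 1 depends on the two methyl groups of its pyrimidine ring or on the ring itself.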